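The compounds below may be only part of what the source reports. "The series", "measured", "known", "first", "only" and "open" are said of these compounds alone.

Working notes on the series. Compound 1 `Cn1c(COc2cccc(C(=O)O)c2)nc2ccc(Oc3ccc(Cl)c(F)c3)nc21` and compound 2 `Cn1c(COc2cccc(C(=O)O)c2)nc2ccc(Oc3cc(Cl)ccn3)cc21` have been measured in a physicochemical assay for lipophilicity, read by LC-MS, in phosphate buffer, measured as octanol-water partition, with a stated time of 30 min, at pH 7.4, tested at 200 mM; on this read-out higher numbers stand for higher lipophilicity and lower numbers for lower lipophilicity: compound 1 gives 2.2 and compound 2 gives 1.2, the lowest of the two numbers, with compound 1 lying higher by a gap beyond the scatter. Among the measured compounds shown here, the two differ in more than one place, so no single step is drawn between them. Compound 3 `Cn1c(COc2cccc(C(=O)O)c2)nc2ccc(Oc3ncc(Cl)cc3F)cc21` is not yet measured; it differs from compound 2 by 5-chloro-3-fluoropyridin-2-yl in place of 4-chloropyridin-2-yl on an oxygen on an aromatic ring. From compound 2 to compound 3 a small upward step of a number 0.30 log units higher from compound 2 to compound 3 (within the scatter) is expected in this assay, near the edge of the scatter. Compound 3 is therefore estimated at 1.5, between 1.1 and 1.9.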

Compound 3, distribution coefficient: 1.3
Estimate against measurement, compound 3: 0.20 log units above; measured number inside the range.
By their numbers in this assay, from the lowest: compounds 2 and 3 (each within the scatter of the next); then compound 1.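

In this assay, 5-chloro-3-fluoropyridin-2-yl in place of 4-chloropyridin-2-yl on an oxygen on an aromatic ring gives a number 0.10 log units higher from compound 2 to compound 3 (within the scatter), the first single-place step read at this position. At this position, the exchange of these two chloropyridinyl groups leaves the read-out within the scatter. Nothing measured here accounts for this result. Among the compounds shown here, the single step changes the chlorine position and adds fluorine together, so their separate contributions remain unresolved. Also open, from the compounds shown here alone, is how an amine or a nitrile in place of the chlorine would read.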